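From Methyl to Phenyl on a Carbamate Chain

The source may report more compounds than this note shows. Statements on the series, on what has been measured and on what is new or still open speak of the compounds shown alone.

In an ADME assay on 184B5 cells (Homo sapiens) for cytotoxicity, read by MTT assay, with a stated time of 72 h (a lower number here means a stronger inhibitor of growth, a higher number a weaker inhibitor of growth), three carbamates sharing one core have been measured:
compound 1 `CCCOC(=O)Nc1ccc([Se]C#N)cc1` gives 9100 nM;
compound 2 `CCCCCCOC(=O)Nc1ccc([Se]C#N)cc1` gives 20000 nM;
compound 3 `CCOC(=O)Nc1ccc([Se]C#N)cc1` gives 18600 nM.

Compound 3 stands second highest of the three numbers. Its nearest neighbour is compound 2, at a 1.1-fold lower number from compound 2 to compound 3 (0.03 log units; within the scatter), so these two cannot be told apart. Compound 1 sits further away, at a 2.0-fold higher number from compound 1 to compound 3 (0.31 log units; beyond the scatter).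

Compound 4 `N#C[Se]c1ccc(NC(=O)OCc2ccccc2)cc1` is the next member, not yet measured. It differs from compound 3 by phenyl in place of methyl on a saturated chain carbon bound to an oxygen next to a carbonyl group.

The steps already seen all change the same chain. The closest comparison is a 2.0-fold higher number from compound 1 to compound 3 (0.31 log units; beyond the scatter), where a single methyl at that chain carbon is removed. Going the other way, adding more chain in a 2.2-fold higher number from compound 1 to compound 2 (0.34 log units; beyond the scatter) raised the number again, so the measured steps point in no single direction, and all of them are modest. A phenyl is larger than anything tried so far, but nothing here shows whether size at this place helps or hurts. The expectation for compound 4 is therefore a step of a 1.2-fold lower number from compound 3 to compound 4 (0.09 log units; within the scatter), too small to count on.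

Compound 4 is expected to give about 15000 nM, somewhere between 6000 nM and 40000 nM.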

Compound 4, concentration for total growth inhibition: 21900 nM
The estimate for compound 4 lay 1.5-fold (0.16 log units) below the measured number, within the range that was stated.
By their numbers in this assay, from the lowest: compound 1; then compounds 3, 2 and 4 (each within the scatter of the next).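

In this assay, for the compounds shown here, phenyl in place of methyl on a saturated chain carbon bound to an oxygen next to a carbonyl group gives a 1.2-fold higher number from compound 3 to compound 4 (0.07 log units; within the scatter) and so makes no difference that can be read, even though phenyl brings one six-membered aromatic ring of carbon only, which no earlier compound carries at this place. Phenyl in place of pentyl gives the same kind of answer, with a 1.1-fold higher number from compound 2 to compound 4 (0.04 log units; within the scatter), so compound 2, compound 3 and compound 4 cannot be told apart, whether the group at this place is a ring or an open chain. Only a 2.4-fold higher number from compound 1 to compound 4 (0.38 log units; beyond the scatter) lies beyond the scatter, which leaves compound 1 with the lowest number of the four, and the ring does not change that picture.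

From the compounds shown here alone, whether an amine or a carboxylic acid at this place, or on the new phenyl ring, would move the number away from this group of three remains open, as does the effect of a chain longer than that of compound 2. The data at hand offer no measurement that explains any of these numbers.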